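Carboxy for hydroxy on a quinoline amide core

This account rests on a few compounds, and the source may have more. Where it says the series, first, only, none or still open, it means among the compounds named here.

Measured compounds:
compound 1 `Cc1c(C(=O)Nc2c(F)cc(-c3cccc(F)c3)cc2F)nc2ccc(F)cc2c1O` — -0.35%
compound 2 `COc1ccc2nc(C(=O)Nc3ccc(-c4ccccc4)cc3)c(C)c(O)c2c1` — 0.13%
compound 3 `Cc1c(C(=O)Nc2c(F)cc(-c3cccc(F)c3)cc2F)nc2ccc(F)cc2c1C(=O)O` — -0.56%

In a functional assay on A-375 cells (Homo sapiens) for antiproliferative activity, read by MTT assay, with a stated time of 24 h, tested at 0.01 ug/mL (a higher number here means a stronger effect of the compound at the concentration tested, a lower number a weaker effect), compound 1 gives -0.35%, compound 2 gives 0.13% and compound 3 gives -0.56%; all three lie within the scatter of one another. Between compound 1 and compound 3 the change is carboxy in place of hydroxy on an aromatic carbon and the step is a number 0.2 percentage points lower from compound 1 to compound 3 (within the scatter). The difference between the core of compound 1 and the core of compound 2 is not broken down here.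

Compound 4 `COc1ccc2nc(C(=O)Nc3ccc(-c4ccccc4)cc3)c(C)c(C(=O)O)c2c1` is not yet measured. It differs from compound 2 by carboxy in place of hydroxy on an aromatic carbon, the same change as that from compound 1 to compound 3. Because a number 0.2 percentage points lower from compound 1 to compound 3 (within the scatter) stays within the scatter, the step from compound 2 to compound 4 in this assay is expected to be similar, a number 0.2 percentage points lower from compound 2 to compound 4 (within the scatter). Compound 4 is therefore estimated at -0.1%, between -5% and 5%.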

Compound 4, a percentage reported as inhibition, at one concentration (the size of the read-out at that concentration, not a potency): 0.35%
For compound 4 the middle estimate is 0.5 percentage points below the measured one, within the range that was stated.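

The change of hydroxy to carboxy gives a number 0.2 percentage points higher from compound 2 to compound 4 (within the scatter) in this assay. Set beside the earlier step, the change reads alike on both cores: the same change on two cores in this assay, a number 0.2 percentage points lower (within the scatter) from compound 1 to compound 3 and a number 0.2 percentage points higher (within the scatter) from compound 2 to compound 4, 0.4 percentage points apart, within the scatter of two such steps. Among the compounds shown here, this shows only that the change leaves the read-out within the scatter on these two cores at this one concentration; it does not show that a real effect of the change carries from one core to the other, as no step here rises beyond the scatter.

Still open, on these data alone, is whether an amine at this position, or a longer chain in place of the methyl group, would move the read-out beyond the scatter in this assay. The compounds shown also leave open how this change behaves on a core with a clear effect in this assay.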